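Chlorines in place of fluorines on the amide aryl: solubility outlook

This account rests on a few compounds, and the source may have more. Where it says the series, first, only, none or still open, it means among the compounds named here.

Measured compounds:
- Compound 1 `COc1ccc2nc(C)cc(OCC(=O)Nc3cc(C)ccc3OC)c2c1` gives 9500 nM in a physicochemical assay for solubility, in phosphate buffer, measured as kinetic solubility, with a stated time of 1 h, at pH 7.4; a higher number here means a more soluble compound, a lower number a less soluble compound.
- Compound 2 `COc1ccc2nc(C)cc(OCC(=O)Nc3ccc(Br)c(C)c3)c2c1` sits at a limit of this assay, < 1000 nM.
- Compound 3 `COc1ccc2nc(C)cc(OCC(=O)Nc3cc(F)cc(F)c3)c2c1` gives 13000 nM in this assay.

Compound 3 holds the highest of the two numbers shown, with compound 1 nearest; the gap between them, a 1.4-fold higher number from compound 1 to compound 3 (0.14 log units; within the scatter), lies within the scatter, so the two are not distinguished here. Compound 4 `COc1ccc2nc(C)cc(OCC(=O)Nc3ccc(Cl)cc3Cl)c2c1` differs from compound 3 in one place: 2,4-dichlorophenyl in place of 3,5-difluorophenyl on an amide-type nitrogen.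

Among the compounds with values here, two measured steps bear on this change. The step of an at least 13-fold higher number from compound 2 to compound 3 (1.11 log units; beyond the scatter) is large, and the step of an at least 9.5-fold lower number from compound 1 to compound 2 (0.97 log units; beyond the scatter) is at least modest; in both, the compound bearing bromine and methyl on the amide aryl is the one at the limit (the limit of < 1000 nM in this assay, at which 1 of the 3 values shown sits). Within the data shown here, compound 4 carries two chlorines on that same aryl, and no measured compound shows what chlorine does here. A lower number for compound 4 than for compound 3 is expected, with a real chance of a limit only, so the step of a 5.2-fold lower number from compound 3 to compound 4 (0.72 log units; beyond the scatter) is estimated as a moderate drop. The estimate for compound 4 is 2500 nM, within a range from 700 nM to 9000 nM.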

Compound 4, solubility: 20500 nM
Beside the measured number, compound 4's estimate is 8.2-fold (0.91 log units) below it; the measured number lies above the stated range.
By their numbers in this assay, from the lowest: compounds 1, 3 and 4 (each within the scatter of the next, the first and the last beyond it). At a limit, below all of these: compound 2.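

The step of a 1.6-fold higher number from compound 3 to compound 4 (0.20 log units; within the scatter) means that 2,4-dichlorophenyl and 3,5-difluorophenyl on the amide-type nitrogen are not distinguished in this assay, so among the compounds shown, two halogens on this aryl ring do not by themselves go with a low number. Within the data shown here, the step of a 2.2-fold higher number from compound 1 to compound 4 (0.33 log units; beyond the scatter) is modest, but it is the first gap beyond the scatter among the compounds with measured numbers rather than a limit, as compound 1 and compound 3 could not be told apart. The step of an at least 20-fold higher number from compound 2 to compound 4 (1.31 log units; beyond the scatter) is large, and compound 2 remains alone at a limit: the limit of < 1000 nM in this assay, at which 1 of the 4 values shown sits.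

Among these compounds, whether the bromine or the methyl group of the 4-bromo-3-methylphenyl ring matters more for that low reading stays open, as the two appear together in the only compound that carries either on this ring alongside no methoxy group. Also open, from the compounds shown here alone, is how the number would respond to a different kind of group on this ring, such as an amine or a carboxylic acid, or to a single chlorine in place of the two.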